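This account rests on a few compounds, and the source may have more. Where it says the series, first, only, none or still open, it means among the compounds named here.

Within the data shown here, compound 1 `Cc1ccc(S(=O)(=O)n2cc(-c3cc(C(F)(F)F)cc(-c4cn(S(=O)(=O)c5ccc(C)cc5)c5cc(Br)ccc45)n3)c3ccc(Br)cc32)cc1` and compound 2 `COc1ccc2c(c1)c(-c1cc(C(F)(F)F)cc(-c3cn(S(=O)(=O)c4ccc(C)cc4)c4ccc(OC)cc34)n1)cn2S(=O)(=O)c1ccc(C)cc1` are the two measured members. In a functional assay on P388 cells (Mus musculus) for inhibition, tested at 100 uM (a lower number here means a weaker effect, a higher number a stronger effect of the compound at the concentration tested), compound 1 gives 8.9%, while compound 2 gives 13.8%; these two numbers lie within the scatter of each other, so neither can be set apart from the other. The next compound, compound 3 `Cc1ccc(S(=O)(=O)n2cc(-c3cc(C(F)(F)F)c(C#N)c(-c4cn(S(=O)(=O)c5ccc(C)cc5)c5cc(Br)ccc45)n3)c3ccc(Br)cc32)cc1`, is derived from compound 1 by one change: cyano in place of hydrogen on an aromatic carbon. Among the measured compounds shown here, no measured pair shows what such a change does, so no step beyond the scatter is expected; the step from compound 1 to compound 3 in this assay is estimated at a number 3.1 percentage points higher from compound 1 to compound 3 (within the scatter). Compound 3 is expected to give about 12%, in a range from 2% to 28%.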

Compound 3, a percentage reported as inhibition, at one concentration (the size of the read-out at that concentration, not a potency): 1.3%
The estimate for compound 3 lay 10.7 percentage points above the measured number; the whole stated range lies above it.
By their numbers in this assay, from the lowest: compounds 3, 1 and 2 (each within the scatter of the next, the first and the last beyond it).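

Cyano in place of hydrogen on an aromatic carbon, ortho to a trifluoromethyl group and two atoms from the ring nitrogen, is the first one-place change available in this series. In this assay it gives a number 7.6 percentage points lower from compound 1 to compound 3 (within the scatter), so this position accepts a nitrile without a step that can be set apart from the scatter. No measured evidence bears on this result.

Still open, as far as these compounds go, is whether an amine or a carboxylic acid at this position would give a step beyond the scatter. From the compounds shown here alone, the effect of the nitrile on the core of compound 2 also remains open.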